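The compounds below may be only part of what the source reports. "The series", "measured", "known", "first", "only" and "open" are said of these compounds alone.

In a functional assay on HT-29 cells (Homo sapiens) for antiproliferative activity, read by MTT assay, with a stated time of 72 h (a lower number here means a stronger inhibitor, a higher number a weaker inhibitor), three compounds sharing one core have been measured: compound 1 `Cc1ccc(N2CCN(C(=S)SCc3ccc4nc(N)nc(N)c4c3)CC2)cc1` gives 3020 nM, compound 2 `Nc1nc(N)c2cc(CSC(=S)N3CCN(c4ccccc4Cl)CC3)ccc2n1` gives 3900 nM, and compound 3 `Nc1nc(N)c2cc(CSC(=S)N3CCN(c4ccccc4F)CC3)ccc2n1` gives 5420 nM. Compound 3 thus stands level with the other two, within the usual scatter. Compound 4 `Nc1nc(N)c2cc(CSC(=S)N3CCN(c4ccccn4)CC3)ccc2n1` differs from it in one place: pyridin-2-yl in place of 2-fluorophenyl on an amine nitrogen in a ring. Two measured swaps at that nitrogen bear on this, a 1.8-fold higher number from compound 1 to compound 3 (0.25 log units; within the scatter) and a 1.3-fold higher number from compound 1 to compound 2 (0.11 log units; within the scatter), as does a 1.4-fold higher number from compound 2 to compound 3 (0.14 log units; within the scatter). All stayed within the scatter, although none introduced a ring with a hetero atom. No step beyond the scatter is therefore expected in this assay. Compound 4 is estimated at 4500 nM, with an expected range of 2000 nM to 10000 nM. The expected change is a 1.2-fold lower number from compound 3 to compound 4 (0.08 log units; within the scatter).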

Compound 4, half-maximal inhibitory concentration: 6200 nM
Estimate against measurement, compound 4: 1.4-fold (0.14 log units) below; the range from low to high includes it.
By their numbers in this assay, from the lowest: compounds 1, 2, 3 and 4 (each within the scatter of the next, the first and the last beyond it).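

Pyridin-2-yl, the first ring with a hetero atom on this amine nitrogen, gives in this assay a 1.1-fold higher number from compound 3 to compound 4 (0.06 log units; within the scatter) and a 1.6-fold higher number from compound 2 to compound 4 (0.20 log units; within the scatter) within a set whose steps are otherwise small. So here, swapping the 2-fluorophenyl or 2-chlorophenyl ring for this one leaves the number level. Only the comparison with 4-methylphenyl passes the scatter, with a 2.1-fold higher number from compound 1 to compound 4 (0.31 log units; beyond the scatter) as a modest step, and nothing available explains it. From the compounds shown here alone, whether a non-aromatic group on this nitrogen, such as a cyclohexyl ring or a longer alkyl chain, would shift the number further remains open.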